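This account rests on a few compounds, and the source may have more. Where it says the series, first, only, none or still open, it means among the compounds named here.

Measured compounds and their numbers:
Compound 1 `Cn1cc(-c2cnc(NCc3c(F)ccc4c3CCO4)c3cn[nH]c(=O)c23)cn1`; in a physicochemical assay for solubility, read by LC-MS, in phosphate buffer, with a stated time of 24 h, at pH 7.4 (on this read-out higher numbers stand for higher solubility and lower numbers for lower solubility), compound 1 gives 1000 nM.
Compound 2 `O=C1CCCN1c1cnc(NCc2c(F)ccc3c2CCO3)n2cnnc12`; in this assay compound 2 gives 640000 nM.
Compound 3 `Cn1nccc1-c1cnc(NCc2c(F)ccc3c2CCO3)c2cn[nH]c(=O)c12`; in this assay compound 3 gives 2000 nM.

Compound 2 stands highest of the three numbers in this assay. Its nearest neighbour is compound 3, and compound 1 lies further off still; both gaps are beyond the scatter. For the measured compounds named here, the only step between measured compounds that differ in one place is a 2.0-fold higher number from compound 1 to compound 3 (0.30 log units; within the scatter), a change on a different core from that of compound 2, and it lies within the scatter.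

Compound 4 `CN(C(=O)c1ccccc1)c1cnc(NCc2c(F)ccc3c2CCO3)n2cnnc12` differs from compound 2 in a single place: benzoyl(methyl)amino in place of 2-oxopyrrolidin-1-yl on an aromatic carbon. Going by the values given here, no measured pair shares this exchange, so no step bears on it directly; the step from compound 1 to compound 3 concerns another core and another pair of groups, and offers no guide to the size or direction here. The expectation therefore rests on the count of what leaves and what enters, and it is held loosely: compound 4 is expected to give a number below that of compound 2, a step of a 6.4-fold lower number from compound 2 to compound 4 (0.81 log units; beyond the scatter). The estimate for compound 4 in this assay is 100000 nM, with a range from 20000 nM to 400000 nM.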

Compound 4, solubility: 280000 nM
Compound 4: middle estimate off by 2.8-fold (0.45 log units), on the low side; measured number inside the range.
By their numbers in this assay, from the lowest: compounds 1 and 3 (each within the scatter of the next); then compound 4; then compound 2.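

In this assay, benzoyl(methyl)amino in place of 2-oxopyrrolidin-1-yl on this aromatic carbon gives a 2.3-fold lower number from compound 2 to compound 4 (0.36 log units; beyond the scatter), a modest step that is beyond the scatter. For the compounds shown here, this position therefore accepts an exchange of the five-membered non-aromatic ring of 6 heavy atoms for a group of 10 heavy atoms carrying a six-membered aromatic ring of carbon only, with the read-out changing by no more than this step, and the count of hydrogen-bond donors and acceptors stays the same on both sides. Going by these compounds alone, the earlier compounds could not show this, since their only step concerns another core and lies within the scatter, and nothing measured here explains the size of the new step.

With only two groups shown at this place, it remains open how an amine such as morpholin-4-yl, a carboxylic acid or the smaller acetyl(methyl)amino would read on the core of compound 2. Going by these compounds, it is also open whether the same exchange would give a step of similar size and direction on the core of compound 1.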